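Removing the basic side chain from a sulfonyl-bearing acid

A few compounds are considered here, and "the series" means these few. Any claim that something is new, unique, unknown or untested is made for them only; others in the source may bear on it.

Measured compounds:
- Compound 1, `COCCN(C)S(=O)(=O)c1ccc(C)c(C#Cc2cc(Cl)ccc2OCC(=O)O)c1`: 4.1 nM
- Compound 2, `CNS(=O)(=O)c1ccc(C)c(C#Cc2cc(Cl)ccc2OCC(=O)O)c1`: 10 nM
- Compound 3, `Cc1ccc(S(=O)(=O)N(C)CCCN(C)C)cc1C#Cc1cc(Cl)ccc1OCC(=O)O`: 287 nM

In an assay on CHO cells for displacement of a labelled ligand from prostaglandin D2 receptor 2 (Homo sapiens), read by scintillation counting (a lower number here means a stronger inhibitor, a higher number a weaker inhibitor), compound 3 shows the highest of the three numbers: a 29-fold higher number from compound 2 to compound 3 (1.46 log units; beyond the scatter) and a 70-fold higher number from compound 1 to compound 3 (1.85 log units; beyond the scatter), both clearly beyond the scatter. Compound 4, `CCS(=O)(=O)c1ccc(C)c(C#Cc2cc(Cl)ccc2OCC(=O)O)c1`, has not yet been measured. It differs from compound 3 in one place: ethyl in place of (3-(dimethylamino)propyl)(methyl)amino on a sulfonyl sulfur. The whole (3-(dimethylamino)propyl)(methyl)amino group, which carried one hydrogen-bond acceptor, is gone, and a plain ethyl stands on the sulfonyl sulfur instead.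

The two steps that bear on this are a 70-fold higher number from compound 1 to compound 3 (1.85 log units; beyond the scatter) and a 29-fold higher number from compound 2 to compound 3 (1.46 log units; beyond the scatter), which both show that adding the 3-(dimethylamino)propyl chain raised the number greatly; a 2.4-fold higher number from compound 1 to compound 2 (0.39 log units; beyond the scatter) shows that the smaller change at the sulfonamide nitrogen mattered only modestly. Among the compounds with values here, because a 29-fold higher number from compound 2 to compound 3 (1.46 log units; beyond the scatter) was large, taking the chain away again in compound 4 is expected to lower the number substantially, toward the level of compound 2, though no measured compound carries an ethyl directly on the sulfonyl sulfur, so the exact level is uncertain. The step is expected to be a 19-fold lower number from compound 3 to compound 4 (1.28 log units; beyond the scatter). For compound 4 the estimate is 15 nM, in the range 4 nM to 60 nM.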

Compound 4, inhibition constant: 8.6 nM
For compound 4 the middle estimate is 1.7-fold (0.24 log units) above the measured one; the measured number falls inside the stated range.
By their numbers in this assay, from the lowest: compound 1; then compounds 4 and 2 (each within the scatter of the next); then compound 3.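

In this assay, the nitrogen on the sulfonyl sulfur turns out not to be required: ethyl in place of methylamino gives a 1.2-fold lower number from compound 2 to compound 4 (0.07 log units; within the scatter). Removing the (3-(dimethylamino)propyl)(methyl)amino group gives a 33-fold lower number from compound 3 to compound 4 (1.52 log units; beyond the scatter), so the high number of compound 3 goes with that group rather than with the shared core. The (2-methoxyethyl)(methyl)amino group still keeps a modest edge over plain ethyl, with a 2.1-fold higher number from compound 1 to compound 4 (0.32 log units; beyond the scatter).

No measurement shown here explains why these groups differ. Also open, from the compounds shown here alone, is how a longer alkyl chain, or a morpholine ring on the sulfonyl sulfur, would read in this assay, and whether a shorter chain ending in an amine would carry the same penalty as compound 3.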